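The source may report more compounds than this note shows. Statements on the series, on what has been measured and on what is new or still open speak of the compounds shown alone.

Measured so far:
- compound 1 `Cc1ccc2c(O)cc(-c3cccc(Cl)c3)nc2n1`: < 10 nM
- compound 2 `Cc1cc(C)c2c(O)cc(-c3cccc(F)c3)nc2n1`: < 10 nM

In a functional assay on MDA-MB-435 cells (Homo sapiens) for antiproliferative activity (on this read-out higher numbers stand for weaker inhibition of growth and lower numbers for stronger inhibition of growth), compound 2 gives < 10 nM, which is a limit of the assay and not a number. Compound 1 gives < 10 nM, also a limit. For the measured compounds named here, the series so far rests entirely on (the limit of < 10 nM in this assay, at which 2 of the 2 values shown sit), so no order can be read between the two compounds, and compound 2 has no exact value to step from.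

Compound 3 `Cc1cc(C)c2c(O)cc(-c3cccc(Cl)c3)nc2n1` has chloro in place of fluoro on an aromatic carbon. The exchange sits on a six-membered aromatic ring of carbon only, meta to a large group.

Going by the values given here, no measured step gauges this exchange. In this assay no change beyond the scatter is expected, resting on compound 1, which also carries chloro and gives < 10 nM. The expected step that the limit leaves unreadable from compound 2 to compound 3 is small. Compound 3 is estimated at 7 nM, with an expected range of 2 nM to 25 nM. Another report as a limit is the likeliest outcome.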

Compound 3, concentration for 50% growth inhibition: 13.2 nM
Beside the measured number, compound 3's estimate is 1.9-fold (0.28 log units) below it; the measured number falls inside the stated range.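

In this assay, for the compounds shown here, compound 3 gives 13.2 nM, the first exact number, so the aromatic carbon carrying the halogen, meta to a large group, now has one firm reading instead of limits alone. Chloro in place of fluoro on an aromatic carbon gives an at least 1.3-fold higher number from compound 2 to compound 3 (0.12 log units; that floor lies within the scatter), and methyl in place of hydrogen on an aromatic carbon gives an at least 1.3-fold higher number from compound 1 to compound 3 (0.12 log units; that floor lies within the scatter). The values of compound 1 and compound 2 are limits of the assay and not numbers, so each step is only a floor with no upper end, because the other end of each rests on a limit: the limit of < 10 nM in this assay, at which 2 of the 3 values shown sit.

Whether the halogen exchange or the added methyl changes growth inhibition by more than the scatter therefore stays unsettled, since an exact number for compound 1 or compound 2 would be needed to size either step. The compounds shown also give no reading for anything other than a halogen at this place on the ring, such as an amine, a methoxy group or a carboxylic acid.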